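Ester swap on the shared core: nitrofuran for chlorophenyl

This account rests on a few compounds, and the source may have more. Where it says the series, first, only, none or still open, it means among the compounds named here.

Values measured in a functional assay on MCF7 cells (Homo sapiens) for antiproliferative activity, read by MTT assay, with a stated time of 72 h (a higher number here means a weaker inhibitor, a lower number a stronger inhibitor), so far:
- compound 1 `CC(=O)O[C@H]1CC[C@]2(C)[C@H](CC[C@@](C)(O)[C@H]2CC[C@@H]2C(C)=CC[C@H]3[C@H](CC[C@]3(C)O)C2(C)C)OC1(C)C` gives 47900 nM
- compound 2 `CC1=CC[C@H]2[C@H](CC[C@]2(C)O)C(C)(C)[C@@H]1CC[C@H]1[C@]2(C)CC[C@H](OC(=O)c3ccccc3Cl)C(C)(C)O[C@H]2CC[C@@]1(C)O` gives 12100 nM

For the measured compounds named here, of these two numbers, compound 2 holds the lower, and compound 1 is its only neighbour. Compound 3 `CC1=CC[C@H]2[C@H](CC[C@]2(C)O)C(C)(C)[C@@H]1CC[C@H]1[C@]2(C)CC[C@H](OC(=O)c3ccc([N+](=O)[O-])o3)C(C)(C)O[C@H]2CC[C@@]1(C)O` keeps the shared core and carries 5-nitrofuran-2-yl in place of 2-chlorophenyl on a carbonyl carbon and nothing else changes.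

Going by the values given here, one measured step bears on this, at the same place (a 4.0-fold lower number from compound 1 to compound 2 (0.60 log units; beyond the scatter)) and it is modest, though beyond the scatter. That step replaced methyl with 2-chlorophenyl. Among the compounds with values here, no measured step yet exchanges one aromatic ring for another, so it gives no firm direction for this change. In this assay no step beyond the scatter is therefore expected, with a slightly lower number at most a weak leaning.

The expected step is a 1.2-fold lower number from compound 2 to compound 3 (0.08 log units; within the scatter) and this remains an estimate. For compound 3 the estimated value is 10000 nM with an expected range (3500 nM to 30000 nM).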

Compound 3, half-maximal inhibitory concentration: 21300 nM
The estimate for compound 3 lay 2.1-fold (0.33 log units) below the measured number; the range from low to high includes it.
By their numbers in this assay, from the lowest: compounds 2 and 3 (each within the scatter of the next); then compound 1.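

In this assay, the exchange on the carbonyl carbon gives a 1.8-fold higher number from compound 2 to compound 3 (0.25 log units; within the scatter), so 2-chlorophenyl and 5-nitrofuran-2-yl are not told apart at this position, even though the two rings differ in ring size, hetero atoms and hydrogen-bond acceptors. Against methyl, 5-nitrofuran-2-yl gives a 2.2-fold lower number from compound 1 to compound 3 (0.35 log units; beyond the scatter), a modest step beyond the scatter, so a second, quite different aromatic ring now stands with 2-chlorophenyl on the lower side of compound 1, and none of the three compounds goes against this. No measured evidence on hand accounts for either step.

The compounds shown leave open whether an aromatic ring is needed at all, or whether a saturated ring such as cyclohexyl, or a longer alkyl chain, on the same carbonyl carbon would give a similar number. Also open, on these data alone, is whether an amine or a carboxylic acid on the ring would move the number beyond the scatter of compound 2, which would show whether this position tolerates more than the neutral groups seen so far.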